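Shortening the alkoxy ring: cyclohexyl to cyclopentyl

A few compounds are considered here, and "the series" means these few. Any claim that something is new, unique, unknown or untested is made for them only; others in the source may bear on it.

Four related sulfonamides carrying a nitro group and an alkoxy substituent were examined in an assay on SK-BR-3 cells for inhibition of Aromatase (Homo sapiens); on this read-out lower numbers stand for stronger inhibition and higher numbers for weaker inhibition. Compound 1 `CCCCCCCCCOc1cc([N+](=O)[O-])ccc1NS(C)(=O)=O` gives 910 nM. Compound 2 `CCCCCCOc1cc([N+](=O)[O-])ccc1NS(C)(=O)=O` gives 2670 nM, and the change a 2.9-fold higher number from compound 1 to compound 2 (0.47 log units; beyond the scatter). Compound 3 `CN(c1ccc([N+](=O)[O-])cc1OC1CCCCC1)S(C)(=O)=O` gives 470 nM; compound 1 sits within the scatter of that number, whereas compound 2 lies beyond it.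

Compound 4 `CN(c1ccc([N+](=O)[O-])cc1OC1CCCC1)S(C)(=O)=O` has not yet been measured in this assay. It differs from compound 3 by cyclopentyl in place of cyclohexyl on an oxygen on an aromatic ring. Among the compounds with values here, the only measured step that bears on this change is the loss of chain carbons from the alkoxy group in going from compound 1 to compound 2, which gave a modest weakening. Removing one ring carbon from compound 3 is a smaller cut, so a step at the edge of the scatter, toward a higher number, is expected: the estimated change is a 1.5-fold higher number from compound 3 to compound 4 (0.17 log units; within the scatter). Compound 4 is therefore expected to give about 700 nM in this assay, with a range from 350 nM to 1400 nM.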

Compound 4, half-maximal inhibitory concentration: 440 nM
For compound 4 the middle estimate is 1.6-fold (0.20 log units) above the measured one; the range from low to high includes it.
By their numbers in this assay, from the lowest: compounds 4, 3 and 1 (each within the scatter of the next, the first and the last beyond it); then compound 2.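

In this assay, replacing cyclohexyl with cyclopentyl on an oxygen on an aromatic ring gives a 1.1-fold lower number from compound 3 to compound 4 (0.03 log units; within the scatter), so the removal of one ring carbon has no readable effect at this position. Within the data shown here, the only earlier step on an alkoxy group, a 2.9-fold higher number from compound 1 to compound 2 (0.47 log units; beyond the scatter), lay beyond the scatter, so here a cut in the ring does not read like the loss of chain carbons, although that step sits on a different core and shortens a chain by more. Nothing measured here accounts for the two ring sizes reading alike.

As far as these compounds go, it remains open whether a smaller cyclopropyl, a larger cycloheptyl or a piperidinyl ring carrying an amine would stay as close to compound 3 . The compounds shown also cannot separate ring from chain on a single core, since the rings and the chains sit on different ones.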